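Replacing the oxazole amide of compound 3 with a methoxyazetidine urea

The source may hold more compounds than are shown below. What is called first, only, known or untested is meant among the compounds shown, and "the series" means these compounds.

Three compounds carry measurements in an ADME assay on the whole organism (Rattus norvegicus, strain Wistar Han) for pharmacokinetics; on this read-out higher numbers stand for fast clearance and lower numbers for slow clearance. Compound 1 `CCn1c(-c2cnc(C)nc2)nc2c(O[C@H]3CCN(C(=O)C4CC4)C3)ncnc21` gives 9.7 mL/min/kg, and compound 2 `CCn1c(-c2cnc(C)nc2)nc2c(N[C@H]3CCN(C(=O)C4CCC4)C3)ncnc21` gives 13 mL/min/kg. Compound 3 `CCn1c(-c2ccc(C(F)(F)F)nc2)nc2c(O[C@H]3CCN(C(=O)c4cocn4)C3)ncnc21` gives 1.3 mL/min/kg, the lowest of the three numbers; its nearest neighbour is compound 1, whose number stands beyond the scatter above it, and compound 2 lies further still, also beyond the scatter.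

Compound 4 `CCn1c(-c2ccc(C(F)(F)F)nc2)nc2c(O[C@H]3CCN(C(=O)N4CC(OC)C4)C3)ncnc21` has not been measured. It differs from compound 3 in one place: 3-methoxyazetidin-1-yl in place of 1,3-oxazol-4-yl on a carbonyl carbon. The change sits on the carbonyl carbon bound to the amide-type nitrogen in the ring, so the (1,3-oxazol-4-yl)carbonyl of compound 3 becomes a (3-methoxyazetidin-1-yl)carbonyl.

For the measured compounds named here, no pair of measured compounds shows this exact change, so the expectation for compound 4 rests on the number of compound 3 alone. The step from compound 3 to compound 4 is expected to be small, most likely within the scatter or a modest rise, as a 1.9-fold higher number from compound 3 to compound 4 (0.28 log units; within the scatter). Compound 4 is therefore estimated at 2.5 mL/min/kg, with a range from 1 mL/min/kg to 6.5 mL/min/kg.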

Compound 4, clearance: 1.7 mL/min/kg
For compound 4 the middle estimate is 1.5-fold (0.17 log units) above the measured one, within the range that was stated.
By their numbers in this assay, from the lowest: compounds 3 and 4 (each within the scatter of the next); then compounds 1 and 2 (each within the scatter of the next).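

In this assay the exchange of 1,3-oxazol-4-yl for 3-methoxyazetidin-1-yl on the carbonyl carbon gives a 1.3-fold higher number from compound 3 to compound 4 (0.12 log units; within the scatter) and so leaves the read-out where it was. For the compounds shown here, this is the first comparison at this position in which only one place differs, and it shows that a five-membered aromatic ring and a four-membered non-aromatic ring can stand on this carbonyl carbon without a change that exceeds the scatter. No other measurement at hand bears on this result.

The compounds shown leave open whether a simple amine such as dimethylamine or a morpholine, attached through the same carbonyl carbon, would also read alike. They also leave open whether this exchange would read the same with the other groups carried by compound 1.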